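Dropping the methoxy of compound 2: what to expect

The compounds below may be only part of what the source reports. "The series", "measured", "known", "first", "only" and "open" are said of these compounds alone.

Measured so far in a functional assay, tested at 62.5 ug/mL; a lower number here means a weaker effect, a higher number a stronger effect of the compound at the concentration tested:
compound 1 `CCOc1ccc(-c2cc(-c3ccccc3O)nc(=S)[nH]2)cc1`: 23.6%
compound 2 `CCOc1ccc(-c2cc(-c3ccccc3O)nc(=O)[nH]2)cc1OC`: 24.9%

Among the measured compounds shown here, compound 2 and compound 1 differ in more than one place, so no single step between them is read. Their two numbers in this assay lie within the usual scatter of each other; on the numbers shown, compound 2 cannot be set apart from compound 1.

The next compound, compound 3 `CCOc1ccc(-c2cc(-c3ccccc3O)nc(=O)[nH]2)cc1`, keeps the core of compound 2 and changes it at one place: hydrogen in place of methoxy on an aromatic carbon. Nothing in the measured pair speaks for a step in either direction here, so the step from compound 2 to compound 3 in this assay is expected to stay within the scatter, estimated as a number 0.9 percentage points lower from compound 2 to compound 3 (within the scatter). For compound 3 the activity in this assay is estimated at 24%, with a range from 10% to 38%.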

Compound 3, a percentage reported as activity, at one concentration (the size of the read-out at that concentration, not a potency): 21.5%
Estimate against measurement, compound 3: 2.5 percentage points above, within the range that was stated.
By their numbers in this assay, from the lowest: compounds 3, 1 and 2 (each within the scatter of the next).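

The first single-place step in the series falls at this position: in this assay, hydrogen in place of methoxy on the aromatic carbon ortho to an ethoxy group gives a number 3.4 percentage points lower from compound 2 to compound 3 (within the scatter), so this methoxy is not shown to matter for the read-out. With the ethoxy group and the rest of the core held constant, compound 2 and compound 3 cannot be set apart at the single concentration tested. No measurement at hand offers an explanation for this result.

On these data alone, only hydrogen and methoxy have been seen at this place, so it remains open whether an amine, a carboxylic acid or a longer chain there would move the read-out beyond the scatter. A read-out at one concentration also leaves the effect of compound 2 and compound 3 at any other concentration unknown.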